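Swapping a Pyrrolidinylmethyl Group for an Acetyl Group

The source may hold more compounds than are shown below. What is called first, only, known or untested is meant among the compounds shown, and "the series" means these compounds.

Compound 1 `CCOC(=O)c1cccc(-c2ccc(O)cc2)c1` gives 100000 nM in an assay on COS-7 cells for inhibition of patatin-like phospholipase domain-containing protein 2 (Mus musculus); on this read-out lower numbers stand for stronger inhibition and higher numbers for weaker inhibition.
Compound 2 `CCOC(=O)c1cccc(-c2ccc([N+](=O)[O-])cc2)c1` gives 95000 nM in this assay.
Compound 3 `CCOC(=O)c1cccc(-c2ccc(CN3CCCC3)cc2)c1` gives only a limit of the assay, > 200000 nM, in this assay.

Compound 3 thus has no number of its own; it sits at the limit of > 200000 nM in this assay, at which 1 of the 3 values shown sits. Compound 4 `CCOC(=O)c1cccc(-c2ccc(C(C)=O)cc2)c1` has not been measured. It differs from compound 3 in one place: acetyl in place of (pyrrolidin-1-yl)methyl on an aromatic carbon.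

Two measured steps lead into compound 3. From compound 1, an at least 2.0-fold higher number from compound 1 to compound 3 (0.30 log units; that floor lies within the scatter). From compound 2, an at least 2.1-fold higher number from compound 2 to compound 3 (0.32 log units; beyond the scatter). In both, a small group on that aromatic carbon was replaced by the (pyrrolidin-1-yl)methyl group, and the number rose to the limit. The step to compound 4 runs the other way: the (pyrrolidin-1-yl)methyl group leaves and a small acetyl group enters. The hydroxy and nitro groups in compound 1 and compound 2 gave values close to each other, so a small group with one hydrogen-bond acceptor seems to land near that level. An expected step of an at least 2.0-fold lower number from compound 3 to compound 4 (0.30 log units; that floor lies within the scatter) would bring compound 4 back into that range. Compound 4 is therefore expected to give 100000 nM, with a range from 40000 nM to 200000 nM.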

Compound 4, half-maximal inhibitory concentration: 200000 nM
For compound 4 the middle estimate is 2.0-fold (0.30 log units) below the measured one, within the range that was stated.
By their numbers in this assay, from the lowest: compounds 2, 1 and 4 (each within the scatter of the next, the first and the last beyond it).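

In this assay, putting acetyl in place of nitro gives a 2.1-fold higher number from compound 2 to compound 4 (0.32 log units; beyond the scatter) and is a modest step, so two small groups on this aromatic carbon can give numbers that differ beyond the scatter. Putting acetyl in place of hydroxy gives a 2.0-fold higher number from compound 1 to compound 4 (0.30 log units; within the scatter) and leaves compound 1 and compound 4 indistinguishable, so acetyl cannot be separated from hydroxy at this position, even though it can be separated from nitro. Going by these compounds, putting acetyl in place of (pyrrolidin-1-yl)methyl gives a number no higher from compound 3 to compound 4 (the limit leaves the size open) and is a step whose size stays open. That size cannot be read, because compound 3 has only a limit of the assay and not a number of its own: the limit of > 200000 nM in this assay, at which 1 of the 4 values shown sits.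

The compounds shown leave open how a carboxylic acid, a primary amine or a longer chain such as butyl on this aromatic carbon would read in this assay and whether any of them would give a clearly lower number. They also leave open the actual number for compound 3 and, with it, how far (pyrrolidin-1-yl)methyl and acetyl lie apart at this position.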